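The compounds below may be only part of what the source reports. "The series", "measured", "known", "first", "only" and "open" are said of these compounds alone.

Measured compounds in the series:
Compound 1 `CC(C)CSc1nc(N)nc2c1ncn2/C=C1/CC1(CO)CO` gives 60000 nM.
Compound 2 `Nc1nc(OCc2ccccc2)c2ncn(/C=C3/CC3(CO)CO)c2n1` is reported only as a limit, > 20000 nM.
Compound 3 `CC(C)Nc1nc(N)nc2c1ncn2/C=C1/CC1(CO)CO` is likewise reported only as a limit, > 20000 nM.

Among the compounds with values here, in an ADME assay on CCRF-HSB-2 cells (Homo sapiens) for cytotoxicity, with a stated time of 7 days (a higher number here means that more compound is tolerated, a lower number that less compound is tolerated), compound 1 holds the only number among the three values shown; the other two sit at the limit of > 20000 nM in this assay, at which 2 of the 3 values shown sit. For that reason the step that the limit leaves unreadable from compound 1 to compound 2 cannot be sized, and the same holds for a step that the limit leaves unreadable from compound 1 to compound 3 and a step that the two limits leave unreadable from compound 2 to compound 3. Compound 1 is therefore the sole anchor for anything new.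

Compound 4 `CCCCCCSc1nc(N)nc2c1ncn2/C=C1/CC1(CO)CO` differs from compound 1 by pentyl in place of isopropyl on a saturated chain carbon bound to a sulfur. Within the data shown here, none of the measured steps touches the chain on the sulfur; each exchanges the whole substituent on the aromatic carbon and is unreadable anyway. Among the measured compounds shown here, no measured step bears on this change, so no shift beyond the scatter is expected in this assay. The estimate for compound 4 is 60000 nM, with a range from 20000 nM to 150000 nM, which amounts to an expected step of no change at the digits printed from compound 1 to compound 4 (within the scatter).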

Compound 4, half-maximal cytotoxic concentration: 60000 nM
Estimate against measurement, compound 4: no gap at the digits printed; the range from low to high includes it.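

In this assay, within the data shown here, the exchange on the sulfur gives no change at the digits printed from compound 1 to compound 4 (within the scatter) and is the first step that can be read. For this one pair of chains, then, pentyl in place of isopropyl on a saturated chain carbon bound to a sulfur moves nothing beyond the scatter in this assay, and it says nothing yet about other chains at this place. The steps from compound 2 and from compound 3 to compound 4 cannot be read, as the values of compound 2 and compound 3 are limits: the limit of > 20000 nM in this assay, at which 2 of the 4 values shown sit.

On these data alone, whether the result holds for a chain longer than hexyl, or for a chain ending in an amine or a carboxylic acid, stays open. As far as these compounds go, how the substituents of compound 2 and compound 3 compare with hexylsulfanyl also stays open while those two compounds stand only as limits.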